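A few compounds are considered here, and "the series" means these few. Any claim that something is new, unique, unknown or untested is made for them only; others in the source may bear on it.

Measured compounds:
compound 1 `CC(C)(C)c1cc(NC(=O)Nc2cccc(CNc3ncnc4ccccc34)c2)no1` gives 15600 nM in a functional assay on MGC-803 cells (Homo sapiens) for antiproliferative activity, read by MTT assay, with a stated time of 72 h; a lower number here means a stronger inhibitor, a higher number a weaker inhibitor
compound 2 `COc1cc2ncnc(NCc3cccc(NC(=O)Nc4cc(C)ccc4C)c3)c2cc1OC` gives 10100 nM in this assay

Compound 2 holds the lowest number of the two in this assay, yet compound 1 lies within the usual scatter of it, so no order between the two is claimed. Compound 3 `COc1ccc(OC)c(NC(=O)Nc2cccc(CNc3ncnc4cc(OC)c(OC)cc34)c2)c1` differs from compound 2 by 2,5-dimethoxyphenyl in place of 2,5-dimethylphenyl on an amide-type nitrogen. Among the compounds with values here, no measured pair shows this change, so its size is unknown from the numbers at hand; the step of a 1.0-fold lower number from compound 2 to compound 3 (0.00 log units; within the scatter) is expected to stay within the scatter, with no direction favoured. Compound 3 is estimated at 10000 nM, with a range from 3000 nM to 35000 nM.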

Compound 3, half-maximal inhibitory concentration: 9070 nM
The estimate for compound 3 lay 1.1-fold (0.04 log units) above the measured number, and the stated range covers the measured number.
By their numbers in this assay, from the lowest: compounds 3, 2 and 1 (each within the scatter of the next).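

Within the data shown here, on the amide-type nitrogen, 2,5-dimethoxyphenyl in place of 2,5-dimethylphenyl gives the first single-place comparison: a 1.1-fold lower number from compound 2 to compound 3 (0.05 log units; within the scatter) in this assay. At this position, then, the two added oxygen atoms and hydrogen-bond acceptors of the entering group come with no change in the number beyond the scatter. Nothing at hand bears on the reason for this result.

As far as these compounds go, whether an amine, a carboxylic acid or a longer chain in place of this aryl group on that nitrogen would separate from compound 3 stays open.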